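The source may report more compounds than this note shows. Statements on the series, on what has been measured and on what is new or still open speak of the compounds shown alone.

In a functional assay on MCF7 cells (Homo sapiens) for inhibition (on this read-out higher numbers stand for weaker inhibition and lower numbers for stronger inhibition), compound 1 `O=C(CC(CC(=O)NC1Cc2ccccc2C1)c1ccccc1)NCCN1CCCCC1` gives > 100000 nM, which is a limit and not a number. Compound 2 `O=C(CC(CC(=O)NC1Cc2ccccc2C1)c1ccccc1)NCCN1CCCC1` gives > 100000 nM, also a limit. Compound 3 `Cc1ccc(C(CC(=O)NCCN2CCCCC2)CC(=O)NC2Cc3ccccc3C2)cc1` gives > 100000 nM, again a limit. All three thus sit at the same ceiling: the limit of > 100000 nM in this assay, at which 3 of the 3 values shown sit.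

Compound 4 `CCN(C(=O)CC(CC(=O)NCCN1CCCCC1)c1ccccc1)C1Cc2ccccc2C1` carries ethyl in place of hydrogen on an amide-type nitrogen of compound 1: ethyl in place of hydrogen on an amide-type nitrogen. Within the data shown here, two measured steps offer the only guide. Changing the saturated ring gives a step that the two limits leave unreadable from compound 1 to compound 2. Adding a methyl gives a step that the two limits leave unreadable from compound 1 to compound 3. Neither has a readable size, and neither concerns this nitrogen, so no clear direction can be expected, and the result will most likely be another limit. The expected change is a number no higher from compound 1 to compound 4 (the limit leaves the size open). Compound 4 is estimated at 100000 nM, with an expected range of 40000 nM to 200000 nM.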

Compound 4, half-maximal inhibitory concentration: > 100000 nM
Compound 4 was reported as a limit; the forecaster's own chance of this, stated with the estimate: 85%; the middle value lies on the limit itself.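

Compound 4, like compound 1, is reported only as a limit, so the step between them cannot be read. In this assay the compounds shown leave open how strongly any of them inhibits, and whether any of these changes shifts that inhibition.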